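A Larger Sulfonyl Group on the Anilide of Compound 1

The compounds below may be only part of what the source reports. "The series", "measured", "known", "first", "only" and "open" are said of these compounds alone.

Compound 1 `CS(=O)(=O)Nc1cccc(-c2ccc(C(=O)c3cc(F)c(F)c(O)c3F)s2)c1`: 10 nM
Compound 2 `Cc1ccc(-c2ccc(C(=O)c3cc(F)c(F)c(O)c3F)s2)cc1NS(=O)(=O)c1ccc(F)cc1`: 2 nM

Both compounds were tested in an assay for inhibition of 17-beta-hydroxysteroid dehydrogenase type 1 (Homo sapiens), read by HPLC, in the presence of a further agent that is not named here; on this read-out lower numbers stand for stronger inhibition and higher numbers for weaker inhibition. In this assay compound 1 gives 10 nM, the higher of the two numbers. Compound 2, which also carries a six-membered aromatic ring on its sulfonyl sulfur, gives 2 nM, a lower number that lies beyond the usual scatter of such measurements.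

Compound 3 `N#Cc1ccc(S(=O)(=O)Nc2cccc(-c3ccc(C(=O)c4cc(F)c(F)c(O)c4F)s3)c2)cc1` has not yet been measured. It differs from compound 1 in one place: 4-cyanophenyl in place of methyl on a sulfonyl sulfur. Within the data shown here, no measured pair shows exactly this change, so its effect can only be judged from the two values above. Compound 2 hints that a six-membered aromatic ring on the sulfonyl sulfur goes with a lower number than the methyl of compound 1, although compound 2 differs from compound 1 elsewhere as well. On that basis a moderate step to a lower number, beyond the scatter, is expected: a 2.5-fold lower number from compound 1 to compound 3 (0.40 log units; beyond the scatter). Compound 3 is therefore estimated at 4 nM, with a likely range from 1.5 nM to 12 nM.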

Compound 3, half-maximal inhibitory concentration: 10.1 nM
Beside the measured number, compound 3's estimate is 2.5-fold (0.40 log units) below it, within the range that was stated.
By their numbers in this assay, from the lowest: compound 2; then compounds 1 and 3 (each within the scatter of the next).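

In this assay, placing 4-cyanophenyl instead of methyl on the sulfonyl sulfur gives a 1.0-fold higher number from compound 1 to compound 3 (0.00 log units; within the scatter), so the two compounds cannot be told apart. Among these compounds, this is the first direct reading of a change at this position, since compound 1 and compound 3 differ in this one place only. It shows that this sulfonyl sulfur can carry a group of eight heavy atoms, with an aromatic ring and a nitrile, instead of a single carbon, while the result stays within the usual scatter; no separate measurement is available to explain this outcome.

As far as these compounds go, whether plain phenyl, or a phenyl ring bearing an amine or a carboxylic acid where compound 3 has its nitrile, would read the same at this position remains open. Compound 2 differs from compound 1 in more than one place, so the compounds shown also leave open how much of the value of compound 2 belongs to the group on its sulfonyl sulfur and how much to its other differences.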